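One more ring swap in a small series

This account rests on a few compounds, and the source may have more. Where it says the series, first, only, none or still open, it means among the compounds named here.

- Compound 1 `Cn1cc(-c2ccc(N(C(=O)NCc3ccccc3)[C@H]3CC[C@H](Nc4ccc(C#N)cn4)CC3)cc2)ccc1=O`: 7.7 ug/mL
- Compound 2 `Cn1cccc(-c2ccc(N(C(=O)NCc3ccccc3)[C@H]3CC[C@H](Nc4ccc(C#N)cn4)CC3)cc2)c1=O`: 4.7 ug/mL

In a physicochemical assay for solubility, read by spectrophotometry, at pH 6.8 (a lower number here means a less soluble compound, a higher number a more soluble compound), compound 2 gives 4.7 ug/mL and compound 1 gives 7.7 ug/mL, two numbers within the scatter of each other. Compound 2 therefore cannot be separated from compound 1 on these data.

Compound 3 `Cn1c(-c2ccc(N(C(=O)NCc3ccccc3)[C@H]3CC[C@H](Nc4ccc(C#N)cn4)CC3)cc2)cccc1=O` has the same atoms as compound 2, joined differently: a group of 8 heavy atoms (6 carbon, 1 nitrogen, 1 oxygen; one six-membered aromatic ring with 1 hetero atom) in place of a group of 8 heavy atoms (6 carbon, 1 nitrogen, 1 oxygen; one six-membered aromatic ring with 1 hetero atom), on an aromatic carbon. The change lies on an aromatic carbon of a six-membered aromatic ring of carbon only, para to a large group.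

Within the data shown here, only one measured step bears on this. That step, a 1.6-fold lower number from compound 1 to compound 2 (0.21 log units; within the scatter), also exchanged one such group for another and stayed within the scatter. One step is thin evidence, but it gives no reason to expect a change beyond the scatter in this assay.

The expected step is a 1.3-fold higher number from compound 2 to compound 3 (0.11 log units; within the scatter). For compound 3, the estimate is 6 ug/mL, with an expected range from 2.5 ug/mL to 15 ug/mL.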

Compound 3, solubility: < 0.09 ug/mL
Compound 3 gave a limit, no number; the forecaster's own chance of this, stated with the estimate: 5%; at least 66-fold (1.82 log units) between middle value and limit.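

In this assay, the earlier pair showed one arrangement of this ring exchanged for another, on the aromatic carbon para to a large group, with the result staying within the scatter. The new result shows that the same kind of exchange, with the same atoms joined differently, can instead give an at least 52-fold lower number from compound 2 to compound 3 (1.71 log units; beyond the scatter), and the comparison with the other earlier compound gives an at least 85-fold lower number from compound 1 to compound 3 (1.93 log units; beyond the scatter). Compound 3 stands at a limit of the assay and not at a number, so both steps give only a minimum size: the limit of < 0.09 ug/mL in this assay, at which 1 of the 3 values shown sits.

The entering and leaving groups match in every count, and the three compounds do not show which feature of the arrangement goes with the drop. Going by these compounds, it also remains open whether an amine or a carboxylic acid on the ring of compound 3 would lift the read-out clear of this limit.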